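A Chlorine for a Methyl on the Shared Core

This account rests on a few compounds, and the source may have more. Where it says the series, first, only, none or still open, it means among the compounds named here.

Of the compounds shown here, three have been measured in an assay on Sf9 cells for inhibition of protein deacetylase HDAC6 (Homo sapiens), read by fluorescence, with a stated time of 40 min, tested at 100 nM; on this read-out lower numbers stand for less inhibition and higher numbers for more inhibition at the one concentration tested (going by the name of the read-out). Compound 1 `Cc1ccccc1-c1nc(CNc2ccc(C(=O)NO)cc2)n(-c2ccccc2)n1` gives 53.2%, the second highest of the three numbers. Its nearest neighbour is compound 2 `O=C(NO)c1ccc(NCc2nc(-c3ccccc3)nn2-c2ccc(Cl)cc2)cc1`, which gives 55.4%, a number within the usual scatter of compound 1, so the two cannot be ranked against each other. The furthest is compound 3 `Nc1ccccc1NC(=O)c1ccc(NCc2nc(-c3ccccc3)nn2-c2ccccc2)cc1`, which gives 5% in this assay, a number far lower than that of compound 1 and well beyond the scatter.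

Compound 4 `O=C(NO)c1ccc(NCc2nc(-c3ccc(Cl)cc3)nn2-c2ccccc2)cc1` has not yet been measured. It differs from compound 1 in one place: 4-chlorophenyl in place of 2-methylphenyl on an aromatic carbon. Within the data shown here, no single-change step between two measured compounds is available for this exchange, so no measured step can be quoted. Compound 2 shows that a 4-chlorophenyl elsewhere on the shared core sits within the scatter of compound 1, whereas compound 3 differs from compound 1 in another part of the molecule.

On that basis the step from compound 1 to compound 4 is expected to be small, a number 1.8 percentage points higher from compound 1 to compound 4 (within the scatter), not clearly beyond the scatter in either direction. Compound 4 is therefore estimated to give 55%, with a likely range from 35% to 75%.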

Compound 4, a percentage reported as inhibition, at one concentration (the size of the read-out at that concentration, not a potency): 67.2%
Beside the measured number, compound 4's estimate is 12.2 percentage points below it, and the stated range covers the measured number.
By their numbers in this assay, from the lowest: compound 3; then compounds 1 and 2 (each within the scatter of the next); then compound 4.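

In this assay, among these compounds, putting 4-chlorophenyl in place of 2-methylphenyl on the aromatic carbon between two ring nitrogen atoms gives a number 14 percentage points higher from compound 1 to compound 4 (beyond the scatter) and is the first measured single-change step in this set, showing that inhibition at the one concentration tested responds to the group held at this carbon. The response appears even though the two groups have the same count of heavy atoms, the same six-membered aromatic ring of carbon only, and no hydrogen-bond donors or acceptors, so these counts do not tell them apart. No measurement shown here explains the difference between the two groups.

The step also changes two things at once, the kind of substituent on the phenyl ring and where it sits, so it cannot show whether losing the methyl, gaining the chlorine, or the new location of the substituent accounts for the higher number. As far as these compounds go, a 2-chlorophenyl or a 4-methylphenyl on this same carbon would pull these apart, and how a larger group such as 4-bromophenyl or 4-methoxyphenyl would read here remains open.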